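The compounds below may be only part of what the source reports. "The series", "measured", "known", "first", "only" and "open" are said of these compounds alone.

Working notes on the series, all read in a functional assay on B16 cells (Mus musculus), read by spectrophotometry, with a stated time of 3 days; on this read-out higher numbers stand for weaker inhibition and lower numbers for stronger inhibition. Compound 1 `S=C(N/N=C/c1cccc2ccccc12)Nc1ccc(Cl)cc1` gives 1900 nM. Compound 2 `COc1ccc(NC(=S)N/N=C/c2cccc3ccccc23)cc1` gives 860 nM. Compound 3 `COc1cccc(NC(=S)N/N=C/c2cccc3ccccc23)c1` gives 830 nM, level with compound 2, as a 1.0-fold lower number from compound 2 to compound 3 (0.02 log units; within the scatter) shows, and clearly under compound 1.

Compound 4 `S=C(NCc1ccccc1)N/N=C/c1cccc2ccccc12` shares the core of compound 3 and carries one change, benzyl in place of 3-methoxyphenyl on an amide-type nitrogen.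

Among the compounds with values here, no measured compound has benzyl at this place, so the data hold no direct precedent. The nearest evidence is the set of steps that alter the group on that same nitrogen. Moving the methoxy group gave no real shift, with a 1.0-fold lower number from compound 2 to compound 3 (0.02 log units; within the scatter). Replacing 4-chlorophenyl gave modest shifts, with a 2.2-fold lower number from compound 1 to compound 2 (0.34 log units; beyond the scatter) and a 2.3-fold lower number from compound 1 to compound 3 (0.36 log units; beyond the scatter). Those steps set the only observed scale in this assay, and the change here is larger in kind than any of them. Compound 3 shares the low end of the three numbers, so a move upward seems more likely than a further fall, though the data cannot settle this.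

A modest rise is expected, estimated as a 1.7-fold higher number from compound 3 to compound 4 (0.23 log units; within the scatter). For compound 4 the estimated value is 1400 nM, with an expected range from 500 nM to 4000 nM.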

Compound 4, half-maximal inhibitory concentration: 270 nM
Compound 4: middle estimate off by 5.2-fold (0.71 log units), on the high side; the measured number lies below the stated range.
By their numbers in this assay, from the lowest: compound 4; then compounds 3 and 2 (each within the scatter of the next); then compound 1.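

At the amide-type nitrogen whose other neighbour is the thiocarbonyl carbon, benzyl in place of 3-methoxyphenyl gives a 3.1-fold lower number from compound 3 to compound 4 (0.49 log units; beyond the scatter) in this assay, and the same group also gives a 3.2-fold lower number from compound 2 to compound 4 (0.50 log units; beyond the scatter) and a 7.0-fold lower number from compound 1 to compound 4 (0.85 log units; beyond the scatter). Within the data shown here, the steps among compounds 1, 2 and 3 showed only what happens when the group on this nitrogen stays a substituted phenyl ring, so compound 4 is the first sign that a change in the kind of group can take this series past the level shared by compounds 2 and 3, and it is the most potent of the four. This step swaps the ring attachment and removes the methoxy group together, so the two changes cannot be told apart, and no measurement shown gives a reason for the fall.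

From the compounds shown here alone, what remains open is whether the gain belongs to the carbon link of benzyl or to the bare ring, which unsubstituted phenyl and 4-methoxybenzyl on this nitrogen would help separate. Going by these compounds, how far the trend runs also stays open, and 2-phenylethyl, a longer chain, or cyclohexylmethyl, which has no aromatic ring, would test that.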